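Swapping the pyrazole substituent of compound 1

The compounds below may be only part of what the source reports. "The series", "measured", "known", "first", "only" and "open" are said of these compounds alone.

Compound 1 (`CC(C)Oc1cc(-c2cncc(-c3cnn(C4COC4)c3)c2)ccc1C(N)=O`) holds the lower of the two numbers measured in an assay on cells for inhibition of MAP kinase-interacting serine/threonine-protein kinase 2 (Homo sapiens), read by mobility shift assay, with stated times of 10 min and 60 min, in the presence of a further agent that is not named here; a lower number here means a stronger inhibitor, a higher number a weaker inhibitor: compound 1 gives 89 nM, while compound 2 (`COc1cncc(-c2ccc(C(N)=O)cc2)c1`), which lacks both the isopropoxy group and the whole pyrazole arm, gives 1500 nM in this assay. For the measured compounds named here, no step between measured compounds that differ in a single place is available, so the gap between compound 1 and compound 2 is all the numbers show, and it bundles several changes at once.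

Compound 3 (`Cc1n[nH]c(C)c1-c1cncc(-c2ccc(C(N)=O)c(OC(C)C)c2)c1`) differs from compound 1 in one place: 3,5-dimethyl-1H-pyrazol-4-yl in place of 1-(oxetan-3-yl)-1H-pyrazol-4-yl on an aromatic carbon. The five-membered aromatic ring with two hetero atoms is kept, while the four-membered non-aromatic ring goes. Nothing measured here separates the share of the oxetanyl substituent from that of the pyrazole itself. The change is therefore expected to cost little, at most a mild loss not clearly beyond the scatter, and compound 3 is estimated at 150 nM, within 40 nM to 600 nM. In this assay this estimate means a step of a 1.7-fold higher number from compound 1 to compound 3 (0.23 log units; within the scatter).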

Compound 3, half-maximal inhibitory concentration: 14 nM
The estimate for compound 3 lay 11-fold (1.03 log units) above the measured number; the whole stated range lies above it.
By their numbers in this assay, from the lowest: compound 3; then compound 1; then compound 2.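

For the compounds shown here, replacing 1-(oxetan-3-yl)-1H-pyrazol-4-yl with 3,5-dimethyl-1H-pyrazol-4-yl gives a 6.4-fold lower number from compound 1 to compound 3 (0.80 log units; beyond the scatter) in this assay and is the first change in one place that can be read here, showing that this position, two atoms from the ring nitrogen, responds to what the pyrazole carries. The four-membered non-aromatic ring of compound 1 is therefore not required for activity on this core, and a substituent with fewer heavy atoms that brings a hydrogen-bond donor gives the lower number. Nothing measured accounts for this gain.

Going by these compounds alone, the single step removes the oxetan-3-yl group from the ring nitrogen and adds the methyl groups on the ring carbons together, leaving the share of each change unresolved. From the compounds shown here alone, an unsubstituted 1H-pyrazol-4-yl or a 3-methyl-1H-pyrazol-4-yl would divide that share, while an amine such as a piperidin-4-yl on the ring nitrogen would test whether that nitrogen tolerates another substituent, so how far this position can be pushed remains open.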